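The compounds below may be only part of what the source reports. "The series", "measured", "known", "first", "only" and "open" are said of these compounds alone.

Compound 3, `CCOC(=O)C1=C(C)NC(C)=C(C(=O)OCC)C1c1ccc(OCC(=O)NNC(=O)c2ccccc2)cc1`, is the compound of interest here. For the measured compounds named here, in a functional assay on the whole organism (strain Wistar) for inhibition, with Rattus norvegicus as the target, read by paw edema, with stated times of 30 min and 0.5 h, at a dose of 20 mg/kg (on this read-out higher numbers stand for more inhibition at the one dose given (going by the name of the read-out) and lower numbers for less inhibition), compound 3 gives 9.1%, which is the second highest of the three numbers measured so far. Its nearest neighbour is compound 1, `CCOC(=O)C1=C(C)NC(C)=C(C(=O)OCC)C1c1ccc(OCC(=O)NCc2ccccc2)cc1`, which in this assay gives 8.33%; compound 2, `CCOC(=O)C1=C(C)NC(C)=C(C(=O)OCC)C1c1ccc(OCC(=O)Nc2c(C)cccc2C)cc1`, gives 15.9%. Both steps onto compound 3, a number 0.8 percentage points higher from compound 1 to compound 3 (within the scatter) and a number 6.8 percentage points lower from compound 2 to compound 3 (within the scatter), stay within the scatter. Compound 4, `CCOC(=O)C1=C(C)NC(C)=C(C(=O)OCC)C1c1ccc(OCC(=O)NNC(=O)CCC(=O)O)cc1`, differs from compound 3 by 2-carboxyethyl in place of phenyl on a carbonyl carbon. Going by the values given here, no measured step touches that carbonyl carbon; the three measured steps, a number 7.6 percentage points higher from compound 1 to compound 2 (within the scatter), a number 0.8 percentage points higher from compound 1 to compound 3 (within the scatter) and a number 6.8 percentage points lower from compound 2 to compound 3 (within the scatter), all alter the amide-type nitrogen and all lie within the scatter. The expected step is therefore a number 0.9 percentage points higher from compound 3 to compound 4 (within the scatter), no more than the scatter. Compound 4 is estimated at 10%, with a range from 2% to 20%.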

Compound 4, a percentage reported as inhibition, in the whole organism at one dose (the size of the read-out at that dose, not a potency): 34.9%
Estimate against measurement, compound 4: 24.9 percentage points below; measured number above the stated range.
By their numbers in this assay, from the lowest: compounds 1, 3 and 2 (each within the scatter of the next); then compound 4.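

In this assay the carbonyl carbon proves to be a place where a change counts: with 2-carboxyethyl in place of phenyl there is a number 25.8 percentage points higher from compound 3 to compound 4 (beyond the scatter), whereas the earlier changes on the amide-type nitrogen all stayed within the scatter. The ((2-carboxyethyl)carbonyl)amino group also stands clear of the other two groups on that nitrogen, with a number 19 percentage points higher from compound 2 to compound 4 (beyond the scatter) and a number 26.6 percentage points higher from compound 1 to compound 4 (beyond the scatter). Nothing available accounts for this rise. The compounds shown leave open whether a methyl ester, a plain propyl chain or a longer chain ending in a carboxylic acid would hold the number.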